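The source may report more compounds than this note shows. Statements on the series, on what has been measured and on what is new or still open speak of the compounds shown alone.

Measured compounds:
Compound 1 `Cc1nn(C)c(Oc2ccc(F)cc2)c1/C=N\OCc1c(Cl)c(-c2ccc(F)cc2)nn1C` gives 8020 nM in a functional assay on HCT-116 cells (Homo sapiens) for antiproliferative activity, read by MTT assay, with a stated time of 72 h; a higher number here means a weaker inhibitor, a lower number a stronger inhibitor.
Compound 2 `Cc1nn(C)c(Oc2ccc(Cl)cc2)c1/C=N\OCc1c(Cl)c(-c2ccc(F)cc2)nn1C` gives 6030 nM in this assay.
Compound 3 `Cc1nn(C)c(Oc2ccc(OC(F)(F)F)cc2)c1/C=N\OCc1c(Cl)c(-c2ccc(F)cc2)nn1C` gives 2310 nM in this assay.

Compound 1 has the highest number of the three, so it is the weakest inhibitor shown; compound 2 lies within the scatter of it, while compound 3 is clearly lower. Compound 4 `Cc1nn(C)c(Oc2ccc(F)cc2)c1/C=N\OCc1c(Cl)c(-c2ccc(Cl)cc2)nn1C` differs from compound 1 by chloro in place of fluoro on an aromatic carbon. For the measured compounds named here, the only measured step of the same kind, a 1.3-fold lower number from compound 1 to compound 2 (0.12 log units; within the scatter), made this exchange on the other six-membered ring and stayed within the scatter; no measured step touches the ring changed here. A step of about that size is therefore expected for compound 4, a 1.2-fold lower number from compound 1 to compound 4 (0.09 log units; within the scatter), not beyond the scatter. Compound 4 is estimated at 6500 nM, within 3200 nM to 13000 nM.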

Compound 4, half-maximal inhibitory concentration: 7250 nM
The estimate for compound 4 lay 1.1-fold (0.05 log units) below the measured number; low and high end bracket the measured number.
By their numbers in this assay, from the lowest: compound 3; then compounds 2, 4 and 1 (each within the scatter of the next).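

For the compounds shown here, changing 4-fluorophenyl to 4-chlorophenyl gives a 1.1-fold lower number from compound 1 to compound 4 (0.04 log units; within the scatter) in this assay, so this ring, unchanged in the earlier compounds, takes chloro in place of fluoro with no shift beyond the scatter. The same exchange on the other six-membered ring, a 1.3-fold lower number from compound 1 to compound 2 (0.12 log units; within the scatter), also stayed within the scatter, so the two rings read alike for this one exchange. Nothing available here explains this result. Still open, on these data alone, is whether an amine or a carboxylic acid at this position would move the number, and whether trifluoromethoxy here would repeat a 3.5-fold lower number from compound 1 to compound 3 (0.54 log units; beyond the scatter) on the other ring.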